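Removing the Ethylamino Group from a Quinone Core

The source may hold more compounds than are shown below. What is called first, only, known or untested is meant among the compounds shown, and "the series" means these compounds.

Compound 1: `CCNC1=CC(=O)C=C(C(C)(C)C)C1=O`; in a functional assay on NCI-H460 cells (Homo sapiens) for cytotoxicity, read by MTT assay, with a stated time of 72 h (a higher number here means a weaker inhibitor, a lower number a stronger inhibitor), compound 1 gives 13000 nM.
Compound 2: `CCCCNC1=CC(=O)C(C[C@]2(C)[C@@H](C)CC[C@]3(C)C(C)=CCC[C@@H]23)=CC1=O`; in this assay compound 2 reaches only a limit, > 100000 nM.
Compound 3: `CCCCCCCCNC1=CC(=O)C(C[C@]2(C)[C@@H](C)CC[C@]3(C)C(C)=CCC[C@@H]23)=CC1=O`; in this assay compound 3 likewise reaches only a limit, > 100000 nM.

For the measured compounds named here, compound 1 thus holds the only number in this set; the two other values are limits, not numbers. Going by the values given here, the single measured step, a step that the two limits leave unreadable from compound 2 to compound 3, cannot be read because both compounds sit at the limit of > 100000 nM in this assay, at which 2 of the 3 values shown sit.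

Compound 4 is `CC(C)(C)C1=CC(=O)C=CC1=O`. It differs from compound 1 by hydrogen in place of ethylamino on a double-bonded ring carbon. Among the compounds with values here, no measured step bears on this change: the one step in the set is unreadable, and it concerns a chain on the amine rather than loss of the amino group itself. With nothing to point in either direction, the step from compound 1 to compound 4 is expected to stay within the scatter, a 1.1-fold lower number from compound 1 to compound 4 (0.03 log units; within the scatter). Compound 4 is therefore estimated at 12000 nM, in a wide range from 2500 nM to 60000 nM.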

Compound 4, half-maximal inhibitory concentration: > 100000 nM
Compound 4: no number, only a limit (the forecaster's own chance of this, stated with the estimate: 15%); middle value at least 8.3-fold (0.92 log units) away from the limit.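

Hydrogen in place of ethylamino on this double-bonded ring carbon gives, in this assay, an at least 7.6-fold higher number from compound 1 to compound 4 (0.88 log units; beyond the scatter). For the compounds shown here, this is the first step in the set that can be read, and it shows that, on the core of compound 1, this position does not tolerate the loss of the ethylamino group without a clear rise in the number. The value of compound 4 is a limit and not a number, so the true size of the step stays unknown, and compound 1 remains the only compound with a measured value:  the limit of > 100000 nM in this assay, at which 3 of the 4 values shown sit.

The compounds shown leave open whether the nitrogen alone or the ethyl chain as well accounts for this difference. A methylamino, dimethylamino or methoxy group at this carbon on the same core would separate these two readings.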